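The source may hold more compounds than are shown below. What is called first, only, known or untested is meant among the compounds shown, and "the series" means these compounds.

Compound 1 `O=C1C(Nc2ccc(I)cc2)=CC(=O)c2c1nc1n2[C@H]2OC[C@@H](O)[C@H]2OC1` and compound 2 `O=C1C=C(Nc2ccccc2)C(=O)c2c1nc1n2[C@H]2OC[C@@H](O)[C@H]2OC1` share one core and differ only in the group on the amine nitrogen. In a functional assay on HeLa cells (Homo sapiens) for inhibition, read by sulforhodamine B assay (a higher number here means a weaker inhibitor, a lower number a stronger inhibitor), compound 1 gives 4010 nM and compound 2 gives 5620 nM; the two numbers lie within the scatter of each other, so neither compound stands apart. Compound 3 `O=C1C(Nc2cccc(Cl)c2)=CC(=O)c2c1nc1n2[C@H]2OC[C@@H](O)[C@H]2OC1` is not yet measured. It differs from compound 1 by 3-chlorophenyl in place of 4-iodophenyl on an amine nitrogen. Among the measured compounds shown here, no measured pair covers this kind of change, so no step beyond the scatter is expected in this assay in either direction. The expected step from compound 1 to compound 3 is a 1.1-fold higher number from compound 1 to compound 3 (0.05 log units; within the scatter). Compound 3 is estimated at 4500 nM, within a range from 1500 nM to 13000 nM.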

Compound 3, half-maximal inhibitory concentration: 7970 nM
Compound 3: middle estimate off by 1.8-fold (0.25 log units), on the low side, and the stated range covers the measured number.
By their numbers in this assay, from the lowest: compounds 1, 2 and 3 (each within the scatter of the next).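

In this assay, 3-chlorophenyl in place of 4-iodophenyl on the amine nitrogen gives a 2.0-fold higher number from compound 1 to compound 3 (0.30 log units; within the scatter). This first measured step at this position stays within the scatter, so exchanging these two aryl groups does not separate compound 1 from compound 3. Nothing on hand bears on the reason for this result. Still open, on these data alone, is whether a benzyl group or a linear alkyl chain on the amine nitrogen would give a step beyond the scatter. The same question stands for a carboxylic acid on the phenyl ring.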